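Methylamino on the aromatic nitrogen: expected step from compound 2

The source may report more compounds than this note shows. Statements on the series, on what has been measured and on what is new or still open speak of the compounds shown alone.

In a functional assay on V79 cells (Cricetulus griseus) for cytotoxicity, read by colony formation (a higher number here means a weaker inhibitor, a lower number a stronger inhibitor), compound 1 (`CCNCC1CCN(c2c(F)cc3c(=O)c(C(=O)O)cn(CC)c3c2F)C1`) gives 160 ug/mL and compound 2 (`CCNCC1CCN(c2c(F)cc3c(=O)c(C(=O)O)cn(CC4CC4)c3c2F)C1`) gives 240 ug/mL as its value. Compound 2 therefore stands within the scatter of compound 1, and the pair supports no ordering.

The next structure is compound 3 (`CCNCC1CCN(c2c(F)cc3c(=O)c(C(=O)O)cn(NC)c3c2F)C1`). The change is methylamino in place of cyclopropylmethyl on an aromatic nitrogen with methylamino in place of cyclopropylmethyl on an aromatic nitrogen.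

Within the data shown here, one measured step bears on this: a 1.5-fold higher number from compound 1 to compound 2 (0.18 log units; within the scatter) with cyclopropyl in place of methyl on a saturated chain carbon bound to an aromatic nitrogen. Among the measured compounds shown here, that step lies within the scatter, but it is only indirect evidence, since no measured compound carries methylamino. With so little to go on, no shift beyond the scatter is expected in this assay and no direction is favoured. The expected step is a 1.2-fold lower number from compound 2 to compound 3 (0.08 log units; within the scatter) and this estimate stays within the scatter. For compound 3 the estimated value is 200 ug/mL with an expected range of 80 ug/mL to 450 ug/mL for the measurement.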

Compound 3, half-maximal inhibitory concentration: > 500 ug/mL
Compound 3: a limit, no number (the forecaster's own chance of this, stated with the estimate: 5%); middle value at least 2.5-fold (0.39 log units) away from the limit.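

On the aromatic nitrogen, methylamino in place of cyclopropylmethyl gives an at least 2.0-fold higher number from compound 2 to compound 3 (0.31 log units; beyond the scatter) in this assay, and methylamino in place of ethyl gives an at least 3.1-fold higher number from compound 1 to compound 3 (0.49 log units; beyond the scatter). Ethyl and cyclopropylmethyl had left this position without any readable difference, so methylamino is the first group in the series to move the number beyond the scatter, in both comparisons towards weaker inhibition. The reading for compound 3 is a limit of the assay and not a number, so both steps give only a minimum and their full size stays unknown: the limit of > 500 ug/mL in this assay, at which 1 of the 3 values shown sits.

The compounds shown leave open whether the shift goes with the nitrogen attached to the aromatic nitrogen or with methylamino as a whole, a question that an unsubstituted amino group, a dimethylamino group or a propyl chain at the same place would help to separate. Also open, from the compounds shown here alone, is whether the step holds when the ethylamino group of the shared core gives way to a primary amine.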